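Changing the aromatic-nitrogen substituent: toxicity expected to stay low

The source may report more compounds than this note shows. Statements on the series, on what has been measured and on what is new or still open speak of the compounds shown alone.

This study concerns a set of compounds that share one core and are tested in an ADME assay on Huh-7 cells (Homo sapiens) for cytotoxicity; on this read-out higher numbers stand for lower toxicity in this test and lower numbers for higher toxicity in this test. Compound 1 has the structure `Cc1ccccc1CNc1nn(-c2ccc(F)cc2F)cc1CNCCN1CCN(C)CC1`. In this assay compound 1 gives > 20000 nM, which is a limit of the assay rather than a number. Compound 3, `CN1CCN(CCNCc2cn(-c3ccc(F)cc3F)nc2C2CCCCC2)CC1`, differs from compound 1 by a cyclohexyl in place of (2-methylbenzyl)amino on an aromatic carbon. In this assay compound 3 gives > 20000 nM, again a limit. The step that the two limits leave unreadable from compound 1 to compound 3 therefore cannot be sized. Compound 2 has the structure `Cc1ccccc1-c1nn(Cc2ccc(F)cc2)cc1CNCCN1CCN(C)CC1`. In this assay compound 2 gives > 20000 nM, once more a limit and not a number, so compound 2 stands where every value shown sits: the limit of > 20000 nM in this assay, at which 3 of the 3 values shown sit.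

The unmeasured compound 4 is `Cc1ccccc1-c1nn(-c2ccc(C(F)(F)F)cc2)cc1CNCCN1CCN(C)CC1`. It differs from compound 2 by 4-(trifluoromethyl)phenyl in place of 4-fluorobenzyl on an aromatic nitrogen. Among the compounds with values here, no measured step involves this kind of change, so nothing among the measured compounds sizes it; what is known is that compounds 1, 2 and 3, each with its own group on the aromatic nitrogen, all reached the limit. Compound 4 is therefore expected to show no movement beyond the scatter, a step of a number no higher from compound 2 to compound 4 (the limit leaves the size open). The estimate for compound 4 is 20000 nM, with a range from 8000 nM to 60000 nM, and the assay is expected most likely to report only a limit again.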

Compound 4, half-maximal cytotoxic concentration: 11000 nM
Compound 4: the middle estimate sits 1.8-fold (0.26 log units) above what was measured; measured number inside the range.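

Within the data shown here, replacing 4-fluorobenzyl with 4-(trifluoromethyl)phenyl on the aromatic nitrogen yields the only value shown in this assay that is a number and not a limit: compound 4 gives 11000 nM. The step is an at least 1.8-fold lower number from compound 2 to compound 4 (0.25 log units; that floor lies within the scatter), so it may be no real change at all, or it may be a larger one, as it starts from a limit and only its smallest possible size is known. Compound 2 marks that starting point, and its value is a limit and not a number: the limit of > 20000 nM in this assay, at which 3 of the 4 values shown sit.

The compounds shown leave open which part of the change matters, as it both removes the carbon link between the aromatic nitrogen and the ring and exchanges a single fluorine for a trifluoromethyl group; a 4-fluorophenyl or a 4-(trifluoromethyl)benzyl group on the same nitrogen, with the 2-methylphenyl group kept, would pull these two apart. Also open, going by these compounds, is whether 4-(trifluoromethyl)phenyl would give a number in the same test alongside the cyclohexyl group of compound 3 or the (2-methylbenzyl)amino group of compound 1.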